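A few compounds are considered here, and "the series" means these few. Any claim that something is new, unique, unknown or untested is made for them only; others in the source may bear on it.

Compound 1, drawn as `C/C(=N/NC(=S)Nc1ccc(Cl)cc1)c1ccccn1`, is the starting point of this small set. In a functional assay on T98G cells (Homo sapiens) for cytotoxicity, read by MTT assay, with a stated time of 48 h (on this read-out lower numbers stand for stronger inhibition and higher numbers for weaker inhibition), compound 1 gives 5.9 nM. Compound 2, drawn as `C/C(=N/NC(=S)Nc1ccc(F)cc1)c1ccccn1`, carries the change (fluoro in place of chloro on an aromatic carbon), and in this assay compound 2 gives 17 nM. The resulting step, a 2.9-fold higher number from compound 1 to compound 2 (0.46 log units; beyond the scatter), is the only measured movement of this change among the compounds shown.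

Compound 3, drawn as `CC(=NNC(=S)Nc1ccc(Cl)cc1)c1ccccn1`, shares its atoms and bonds with compound 1; the difference between the two cores is the two compounds have the same atoms and bonds; at least one stereo element is drawn with a configuration in one of them and without one in the other: 1 of 1 stereo elements differ; a double bond is drawn Z in compound 1 and without a configuration in compound 3. In this assay compound 3 gives 5.9 nM, and the step of no change at the digits printed from compound 1 to compound 3 (within the scatter) is what one would expect given (the fact that one of compounds 1 and 3 is drawn with a defined configuration and the other without, at the place where they differ), since the two drawings describe the same connectivity. Compound 3 therefore stands level with compound 1, and both sit at the low end of the three measured numbers, with compound 2 the furthest away.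

Compound 4, drawn as `CC(=NNC(=S)Nc1ccc(F)cc1)c1ccccn1`, is not yet measured. It differs from compound 3 by fluoro in place of chloro on an aromatic carbon, the same change that took compound 1 to compound 2, at the same place on the ring. Within the data shown here, from compound 3 to compound 4 a step of a 2.9-fold higher number from compound 3 to compound 4 (0.46 log units; beyond the scatter) is therefore expected, resting on the one measured instance, a 2.9-fold higher number from compound 1 to compound 2 (0.46 log units; beyond the scatter), and on the fact that compound 3 and compound 1 give the same number. For compound 4 in this assay a value of 17 nM is estimated, expected to fall between 8 nM and 36 nM.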

Compound 4, half-maximal inhibitory concentration: 17 nM
Compound 4: middle estimate and measured number agree at the digits printed, within the range that was stated.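

In this assay the exchange of chloro for fluoro gives a 2.9-fold higher number from compound 3 to compound 4 (0.46 log units; beyond the scatter), and set beside the earlier step, the change carries over from one core to the other without a gap beyond the scatter: the same change on two cores in this assay, a 2.9-fold higher number (0.46 log units; beyond the scatter) from compound 1 to compound 2 and a 2.9-fold higher number (0.46 log units; beyond the scatter) from compound 3 to compound 4, 1.0-fold (0.00 log units) apart, within the scatter of two such steps. The step of no change at the digits printed from compound 2 to compound 4 (within the scatter) fits this reading, as these two compounds differ only in whether a double bond is drawn with a configuration: the fact that one of compounds 2 and 4 is drawn with a defined configuration and the other without, at the place where they differ. This shows that the change reads alike on the core of compound 1 and the core of compound 3, but those two cores share their atoms and bonds, so the agreement rests on two closely related pairs in a single assay and does not show that the step would hold on a core with different connectivity.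

The compounds shown leave open how other groups in the same place on the ring would read, such as a bromo, methyl, methoxy or trifluoromethyl group, or an unsubstituted ring carbon. They also leave open whether the step from chloro to fluoro would persist on a core carrying a new group elsewhere, such as an amine, a carboxylic acid or a longer chain, and whether it would appear in any assay other than this assay.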